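The source may report more compounds than this note shows. Statements on the series, on what has been measured and on what is new or still open speak of the compounds shown alone.

Measured so far:
compound 1 `COc1ccc(C2=C(c3ccc(SC)cc3)CC3CCCN3C2=O)cc1C` — 100 nM
compound 2 `CSc1ccc(C2=C(c3ccc(O)c(O)c3)C(=O)N3CCCC3C2)cc1` — 60000 nM
compound 3 `CSc1ccc(C2=C(c3ccc(F)cc3)C(=O)N3CCCC3C2)cc1` — 250 nM

All three values come from a functional assay on NCI-H520 cells (Homo sapiens) for cytotoxicity; a higher number here means a weaker inhibitor of growth, a lower number a stronger inhibitor of growth. Compound 1 stands lowest of the three numbers: the nearest is compound 3, reached by a 2.5-fold higher number from compound 1 to compound 3 (0.40 log units; beyond the scatter), and the furthest is compound 2, reached by a 600-fold higher number from compound 1 to compound 2 (2.78 log units; beyond the scatter). Both of these steps change only the aryl group on the double-bonded ring carbon of the shared core, so both bear on the unmeasured compound 4 `CSc1ccc(C2=C(c3ccc(SC)cc3)C(=O)N3CCCC3C2)cc1`, which differs from compound 1 in the same place: 4-(methylsulfanyl)phenyl in place of 4-methoxy-3-methylphenyl on a double-bonded ring carbon.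

Among the measured compounds shown here, of the two measured steps, the one to compound 2 is large, while the one to compound 3 is modest. The group entering compound 4 is the same 4-(methylsulfanyl)phenyl that already sits on the other double-bonded ring carbon in every compound of the series, and it carries, as the leaving group does, no hydrogen-bond donor and one acceptor. The step for compound 4 is therefore expected to be small, at most of the order of the step to compound 3 and in the same direction, so that a 1.5-fold higher number from compound 1 to compound 4 (0.18 log units; within the scatter) is expected. Compound 4 is estimated at 150 nM, with a range from 60 nM to 400 nM.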

Compound 4, concentration for 50% growth inhibition: 15000 nM
Compound 4: middle estimate off by 100-fold (2.00 log units), on the low side; the whole stated range lies below it.
By their numbers in this assay, from the lowest: compound 1; then compound 3; then compound 4; then compound 2.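

In this assay, matching counts of hydrogen-bond donors and acceptors and nearly the same heavy-atom count do not make two groups interchangeable at this double-bonded ring carbon: a 150-fold higher number from compound 1 to compound 4 (2.18 log units; beyond the scatter) follows when 4-(methylsulfanyl)phenyl replaces 4-methoxy-3-methylphenyl. The outcome also turns on a single substituent of the aryl ring, since methylsulfanyl in place of fluoro gives a 60-fold higher number from compound 3 to compound 4 (1.78 log units; beyond the scatter) and places compound 4 much nearer the 3,4-dihydroxyphenyl analogue, with a 4.0-fold lower number from compound 2 to compound 4 (0.60 log units; beyond the scatter) as the remaining gap, so the three non-catechol aryl groups do not form one tight group here. Nothing at hand gives a measured reason for the loss seen with compound 4.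

The compounds shown leave open whether the loss follows the sulfur atom or the whole methylsulfanyl group, which an ethylsulfanyl, a methoxy or an amino group on the same aryl ring would help separate. They also leave open whether the methoxy or the methyl of compound 1 carries its standing, a question that plain 4-methoxyphenyl and 3-methylphenyl analogues would address.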